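A few compounds are considered here, and "the series" means these few. Any claim that something is new, unique, unknown or untested is made for them only; others in the source may bear on it.

Measured compounds in a functional assay on 8305C cells (Homo sapiens) for cytotoxicity, read by MTT assay, with a stated time of 24 h; on this read-out higher numbers stand for weaker inhibition and lower numbers for stronger inhibition:
compound 1 `CN1O[C@@H](n2cc(-c3ccccc3)nn2)C[C@@H]1CO` gives 7140 nM
compound 2 `CN1O[C@@H](n2ccnn2)C[C@@H]1CO` gives 7960 nM
compound 3 `CCCc1cn([C@H]2C[C@H](CO)N(C)O2)nn1` gives 5820 nM

Compound 1 stands second highest of the three numbers; the nearest is compound 2 with a 1.1-fold higher number from compound 1 to compound 2 (0.05 log units; within the scatter), the furthest is compound 3 with a 1.2-fold lower number from compound 1 to compound 3 (0.09 log units; within the scatter). Between compound 2 and compound 3 there is a 1.4-fold lower number from compound 2 to compound 3 (0.14 log units; within the scatter). All three numbers thus sit within the scatter of one another, and no order among them can be read.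

Compound 4 `COc1ccc(-c2cn([C@H]3C[C@H](CO)N(C)O3)nn2)cc1` differs from compound 1 by methoxy in place of hydrogen on an aromatic carbon. Going by the values given here, no measured step touches the phenyl ring itself; the steps that bear on this region are those in which the whole phenyl was exchanged for hydrogen or propyl, and each of these stayed within the scatter. Changes at this part of the shared core have so far left this assay unchanged, so for compound 4 no step beyond the scatter is expected in either direction, that is a 1.0-fold lower number from compound 1 to compound 4 (0.01 log units; within the scatter). Compound 4 is therefore estimated at 7000 nM, with a range from 3500 nM to 14000 nM.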

Compound 4, half-maximal inhibitory concentration: 8010 nM
For compound 4 the middle estimate is 1.1-fold (0.06 log units) below the measured one; the range from low to high includes it.
By their numbers in this assay, from the lowest: compounds 3, 1, 2 and 4 (each within the scatter of the next).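

Methoxy in place of hydrogen on an aromatic carbon, para to a large group, is the only step here that alters the phenyl ring itself rather than exchanging it whole, and in this assay it gives a 1.1-fold higher number from compound 1 to compound 4 (0.05 log units; within the scatter). Adding a group at this position on the retained ring therefore stays within the scatter, as the exchanges of the whole phenyl for hydrogen or propyl did, so all four compounds remain without a readable order. No measured evidence bears on this result.

From the compounds shown here alone, it remains open whether an amine or a carboxylic acid at this ring position, or a chain longer than propyl on the aromatic carbon of the five-membered ring's place of substitution, would give a step beyond the scatter. The compounds shown also leave open whether methoxy elsewhere on the phenyl ring would behave the same way.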